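The source may hold more compounds than are shown below. What is called first, only, known or untested is meant among the compounds shown, and "the series" means these compounds.

Compound 1 (`COc1ccc(C[C@H]2COC(=O)[C@@H]2Cc2ccc(OCc3cn(Cc4ccc(Cl)cc4)nn3)c(OC)c2)cc1OC`), compound 2 (`COc1ccc(C[C@H]2COC(=O)[C@@H]2Cc2ccc(OCc3cn(-c4ccc(Br)cc4)nn3)c(OC)c2)cc1OC`) and compound 3 (`COc1ccc(C[C@H]2COC(=O)[C@@H]2Cc2ccc(OCc3cn(Cc4ccccc4F)nn3)c(OC)c2)cc1OC`) share one core and differ only in the group on the aromatic nitrogen. In an ADME assay on HeLa cells (Homo sapiens) for cytotoxicity, read by MTT assay (on this read-out lower numbers stand for stronger inhibition and higher numbers for weaker inhibition), compound 1 gives 242000 nM, and compound 2 gives 128000 nM. Compound 3 reached only a limit of the assay, >= 600000 nM, so its true number is not known. Compound 4 (`COc1ccc(C[C@H]2COC(=O)[C@@H]2Cc2ccc(OCc3cn(Cc4ccc(F)cc4)nn3)c(OC)c2)cc1OC`) differs from compound 3 by 4-fluorophenyl in place of 2-fluorophenyl on a saturated chain carbon bound to an aromatic nitrogen. Among the compounds with values here, two measured steps bear on this: an at least 2.4-fold higher number from compound 1 to compound 3 (0.39 log units; beyond the scatter) and an at least 4.6-fold higher number from compound 2 to compound 3 (0.67 log units; beyond the scatter), both ending at the 2-fluorobenzyl of compound 3. Compound 4 carries a 4-fluorobenzyl, resembling the 4-chlorobenzyl of compound 1, which gave 242000 nM. The step is therefore expected to read an at least 1.5-fold lower number from compound 3 to compound 4 (0.17 log units; that floor lies within the scatter), toward a lower number. Compound 4 is estimated at 400000 nM, within a range from 150000 nM to 800000 nM.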

Compound 4, half-maximal inhibitory concentration: 198000 nM
Beside the measured number, compound 4's estimate is 2.0-fold (0.31 log units) above it; the measured number falls inside the stated range.
By their numbers in this assay, from the lowest: compounds 2, 4 and 1 (each within the scatter of the next). At a limit, above all of these: compound 3.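

Moving the fluoro from 2-fluorobenzyl to 4-fluorobenzyl, with the same atoms joined differently, gives an at least 3.0-fold lower number from compound 3 to compound 4 (0.48 log units; beyond the scatter), so the arrangement of this group alone can shift the result. Compound 3 stands only at a limit: the limit of >= 600000 nM in this assay, at which 1 of the 4 values shown sits. Fluoro in place of chloro gives a 1.2-fold lower number from compound 1 to compound 4 (0.09 log units; within the scatter), and 4-fluorobenzyl in place of 4-bromophenyl gives a 1.5-fold higher number from compound 2 to compound 4 (0.19 log units; within the scatter), so neither change separates these compounds.

On these data alone, the true number of compound 3 remains unknown. Also open, as far as these compounds go, is how an amine or a carboxylic acid in place of the fluoro would read.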